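Trifluoromethoxyphenyl for Chloro: Expected Liver Microsome Clearance

The compounds below may be only part of what the source reports. "The series", "measured", "known", "first", "only" and "open" are said of these compounds alone.

Compound 1 `O=C(N[C@H]1CCC[C@H](CO)C1)C1CCN(c2nc3cc(Cl)c(Cl)cc3o2)CC1` is one of two compounds read in an ADME assay on microsomes from liver (Homo sapiens) for metabolic stability; on this read-out higher numbers stand for fast clearance and lower numbers for slow clearance. In this assay compound 1 gives 27.1 mL/min/kg. Compound 2 `N#Cc1ccc2oc(N3CCC(C(=O)N[C@H]4CCC[C@H](CO)C4)CC3)nc2c1` is the other compound measured. In this assay compound 2 returns only < 8 mL/min/kg, which is a limit of the assay rather than a number. Going by the values given here, compound 1 therefore stands as the only numeric value shown. Compound 2 accounts for (the limit of < 8 mL/min/kg in this assay, at which 1 of the 2 values shown sits). Among the compounds with values here, no step between two measured compounds is available, as compounds 1 and 2 differ in more than one place.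

Compound 3 `O=C(N[C@H]1CCC[C@H](CO)C1)C1CCN(c2nc3cc(Cl)c(-c4ccc(OC(F)(F)F)cc4)cc3o2)CC1` differs from compound 1 in a single place: 4-(trifluoromethoxy)phenyl in place of chloro on an aromatic carbon. The change is 4-(trifluoromethoxy)phenyl in place of chloro on an aromatic carbon, ortho to a chloro group, meta to a fused ring and para to a fused ring. Within the data shown here, with no measured step to lean on, the expectation for compound 3 is a moderate increase in clearance beyond the usual scatter, the step of a 1.7-fold higher number from compound 1 to compound 3 (0.22 log units; within the scatter) being an estimate only. Compound 3 is accordingly expected to give 45 mL/min/kg in this assay, with a range from 20 mL/min/kg to 95 mL/min/kg.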

Compound 3, clearance: 50.8 mL/min/kg
Compound 3: middle estimate off by 1.1-fold (0.05 log units), on the low side, within the range that was stated.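

At this position, an aromatic carbon ortho to a chloro group, meta to a fused ring and para to a fused ring, the study now has its first step between two measured compounds that differ in one place. Although 4-(trifluoromethoxy)phenyl brings 11 heavy atoms and a six-membered aromatic ring where chloro had 1 heavy atom, this assay shows a 1.9-fold higher number from compound 1 to compound 3 (0.27 log units; within the scatter), so even this large exchange does not separate the two compounds on this read-out. Nothing shown offers a cause for this outcome.

This single step cannot say whether the phenyl ring or the trifluoromethoxy group on it contributes more to the read-out, and a plain phenyl at the same carbon would be needed to separate the two. It also leaves open how a carboxylic acid or an amine would read at this position, and whether a step beyond the scatter can be found here at all.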